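This account rests on a few compounds, and the source may have more. Where it says the series, first, only, none or still open, it means among the compounds named here.

Measured in a functional assay on HepG2 cells (Homo sapiens) for inhibition, read by MTT assay, with a stated time of 72 h; on this read-out higher numbers stand for weaker inhibition and lower numbers for stronger inhibition:
compound 1, `Cc1noc(C)c1-c1cnc(N)c(Oc2ccc(C(=O)NC3CC3)cc2)n1`: 43200 nM
compound 2, `Cc1noc(C)c1-c1cnc(N)c(Oc2ccc(C(=O)Nc3ccccc3)cc2)n1`: 11800 nM
compound 3, `Cn1cc(-c2cnc(N)c(Oc3ccc(C(=O)Nc4ccccc4)cc3)n2)cn1`: 11600 nM

In this assay compound 3 gives the lowest of the three numbers, but its gap to compound 2 is within the scatter, so no order between compound 2 and compound 3 is read; only compound 1 stands apart, with the higher number.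

Compound 4, `Cn1cc(-c2cnc(N)c(Oc3ccc(C(=O)Nc4cccc(Cl)n4)cc3)n2)cn1`, differs from compound 3 in one place: 6-chloropyridin-2-yl in place of phenyl on an amide-type nitrogen. The phenyl leaves and the 6-chloropyridin-2-yl enters on the amide-type nitrogen whose other neighbour is the carbonyl carbon; one hydrogen-bond acceptor and a chlorine are added there.

For the measured compounds named here, of the measured steps, only a 3.7-fold lower number from compound 1 to compound 2 (0.56 log units; beyond the scatter) touches the same amide-type nitrogen, and it is the one step beyond the scatter, so this position can move the number. It compares cyclopropyl with phenyl, however, not phenyl with a six-membered aromatic ring holding one hetero atom. a 1.0-fold lower number from compound 2 to compound 3 (0.01 log units; within the scatter) lies elsewhere and is flat. Going by the values given here, no measured pair shows an aryl-to-heteroaryl exchange on this nitrogen, so the direction of any step is not read from the series. For compound 4 the expected step is a 1.3-fold lower number from compound 3 to compound 4 (0.11 log units; within the scatter), that is, nothing clearly beyond the scatter, with the range kept open on both sides. Compound 4 is estimated at 9000 nM, between 3000 nM and 30000 nM.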

Compound 4, half-maximal inhibitory concentration: 44200 nM
Beside the measured number, compound 4's estimate is 4.9-fold (0.69 log units) below it, outside the stated range (above it).
By their numbers in this assay, from the lowest: compounds 3 and 2 (each within the scatter of the next); then compounds 1 and 4 (each within the scatter of the next).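

In this assay, for the compounds shown here, 6-chloropyridin-2-yl in place of phenyl on the amide-type nitrogen gives a 3.8-fold higher number from compound 3 to compound 4 (0.58 log units; beyond the scatter), the first measured exchange of one aromatic ring for another at this nitrogen and a change in the direction of weaker inhibition. Going by these compounds alone, the only earlier step at this nitrogen, a 3.7-fold lower number from compound 1 to compound 2 (0.56 log units; beyond the scatter), ran the other way, so the position can now be read as moving the number in both directions, with each step beyond the scatter, and an aromatic ring here is not enough to keep the lower number of compound 3. Nothing on hand gives a measured property or other evidence that bears on this rise.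

The step adds a ring nitrogen and a chlorine together, so the compounds shown do not tell which of the two goes with the higher number; pyridin-2-yl without the chlorine and 3-chlorophenyl on the same nitrogen would separate them. Also open, going by these compounds, is whether the step holds with 3,5-dimethyl-1,2-oxazol-4-yl in place of 1-methyl-1H-pyrazol-4-yl on the shared core.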